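Amide variation on a shared core: paw edema readings

A few compounds are considered here, and "the series" means these few. Any claim that something is new, unique, unknown or untested is made for them only; others in the source may bear on it.

Measured so far:
compound 1 `CN(C)CCNC(=O)c1c(O)c2cccnc2n(-c2ccccc2)c1=O` gives 22.6%
compound 2 `O=C(NC1CCN(Cc2ccccc2)CC1)c1c(O)c2cccnc2n(-c2ccccc2)c1=O` gives 1.7%

In a functional assay on the whole organism for inhibition, with Rattus norvegicus as the target, read by paw edema, at a dose of 100 mg/kg by the oral route (on this read-out lower numbers stand for less inhibition and higher numbers for more inhibition at the one dose given (going by the name of the read-out)), compound 1 gives 22.6%, the higher of the two numbers. Compound 2 gives 1.7%, a gap beyond the usual scatter. Compound 3 `O=C(Nc1ccc([N+](=O)[O-])cc1)c1c(O)c2cccnc2n(-c2ccccc2)c1=O` is not yet measured. It differs from compound 1 in one place: 4-nitrophenyl in place of 2-(dimethylamino)ethyl on an amide-type nitrogen. Going by the values given here, no step between measured compounds isolates this change, so nothing measured speaks for a large move in either direction; the step is estimated as small, if anything downward: a number 7.6 percentage points lower from compound 1 to compound 3 (within the scatter). Compound 3 is expected to give about 15%, with the likely range running from 0% to 35%.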

Compound 3, a percentage reported as inhibition, in the whole organism at one dose (the size of the read-out at that dose, not a potency): -7.6%
Compound 3: the middle estimate sits 22.6 percentage points above what was measured, and the stated range ends above it.
By their numbers in this assay, from the lowest: compounds 3 and 2 (each within the scatter of the next); then compound 1.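

The swap of 2-(dimethylamino)ethyl for 4-nitrophenyl on the amide-type nitrogen reads in this assay as a number 30.2 percentage points lower from compound 1 to compound 3 (beyond the scatter) and gives the series its first step that changes one place only. This position can therefore move the read-out by a large margin. Nothing at hand ties that step to any property of either group.

Open, as far as these compounds go, is whether the loss of the amine or the arrival of the aromatic ring carries the step. An unsubstituted phenyl, a longer dialkylaminoalkyl chain or a carboxylic acid on this nitrogen would help separate the two.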